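Phenyl ureas: what compound 4 may do

The source may hold more compounds than are shown below. What is called first, only, known or untested is meant among the compounds shown, and "the series" means these compounds.

Compound 1 `COc1cc(NC(C)CCCNC(=O)Nc2ccc(F)cc2)c2ncccc2c1` gives 26000 nM in a functional assay on CCRF-CEM cells (Homo sapiens) for inhibition, read by MTT assay, with a stated time of 72 h (on this read-out higher numbers stand for weaker inhibition and lower numbers for stronger inhibition), and compound 2 `COc1cc(NC(C)CCCNC(=O)Nc2ccc(C(F)(F)F)cc2)c2ncccc2c1` gives 14000 nM there, while compound 3 `COc1cc(NC(C)CCCNC(=O)Nc2cccc(C(F)(F)F)c2)c2ncccc2c1` gives 19000 nM on the same read-out. Compound 3 is not separated from the other two: a 1.4-fold lower number from compound 1 to compound 3 (0.14 log units; within the scatter) and a 1.4-fold higher number from compound 2 to compound 3 (0.13 log units; within the scatter) both stay within the scatter.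

Compound 4 `COc1cc(NC(C)CCCNC(=O)NNC(=O)Nc2ccc(O)cc2)c2ncccc2c1` is still unmeasured. It carries ((4-hydroxyphenyl)carbamoyl)amino in place of 3-(trifluoromethyl)phenyl on an amide-type nitrogen. The three measured steps only exchange one substituted phenyl group for another, so they bear on this change loosely. Going by the values given here, no measured compound has the entering group. Even the widest of these steps, a 1.9-fold lower number from compound 1 to compound 2 (0.27 log units; within the scatter) as measured, stays within the scatter, which gives no ground for expecting a large move. In this assay the expected step (a 1.3-fold higher number from compound 3 to compound 4 (0.12 log units; within the scatter)) is therefore none beyond the scatter, with a weak lean to a higher number. The estimate for compound 4 is 25000 nM (expected range 9000 nM to 70000 nM).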

Compound 4, half-maximal inhibitory concentration: 111000 nM
The estimate for compound 4 lay 4.4-fold (0.65 log units) below the measured number, and the stated range ends below it.
By their numbers in this assay, from the lowest: compounds 2, 3 and 1 (each within the scatter of the next); then compound 4.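

On the amide-type nitrogen whose other neighbour is the carbonyl carbon, exchanges of one substituted phenyl group for another stayed within the scatter, but ((4-hydroxyphenyl)carbamoyl)amino gives weaker inhibition in this assay against all three: a 5.8-fold higher number from compound 3 to compound 4 (0.77 log units; beyond the scatter), a 7.9-fold higher number from compound 2 to compound 4 (0.90 log units; beyond the scatter) and a 4.3-fold higher number from compound 1 to compound 4 (0.63 log units; beyond the scatter). This position therefore does respond to change, and the loss appears whichever of the three phenyl groups is taken as the reference. Nothing available explains the loss.

The entering group differs from the phenyl groups both in its carbamoyl-amino link and in its hydroxy group, and the compounds shown do not separate the two. Also open, on these data alone, is how a simple aminophenyl group or a carboxylic acid on this nitrogen would read out.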